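The source may hold more compounds than are shown below. What is called first, only, known or untested is meant among the compounds shown, and "the series" means these compounds.

Working notes on the series. Two members have a number in a functional assay on CHO cells for agonist activity at Free fatty acid receptor 1 (Homo sapiens), read by FLIPR and calcium flux, tested at 100 nM (a lower number here means a weaker effect, a higher number a stronger effect of the compound at the concentration tested), so far. Compound 1 `O=C(O)CC1COc2cc(OCc3nnc(-c4ccccc4)o3)ccc21` gives 1.54% in this assay. Compound 2 `Cc1nc(-c2ccc(Cl)s2)sc1COc1ccc2c(c1)OCC2CC(=O)O` gives 8.34% in this assay; the two numbers sit within the usual scatter of each other, so nothing separates compound 1 and compound 2 on these data. For the measured compounds named here, no step between measured compounds that differ in one place has been recorded, and no pattern can be drawn from two compounds that agree within the scatter.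

Compound 3 `Cc1nc(-c2cccc(Cl)c2)sc1COc1ccc2c(c1)OCC2CC(=O)O` is the next member to be run in this assay. It differs from compound 2 in one place: 3-chlorophenyl in place of 5-chlorothiophen-2-yl on an aromatic carbon. With only compound 2 at 8.34% as a reference, the step from compound 2 to compound 3 is expected to be small, none beyond the scatter, as a number 0.3 percentage points lower from compound 2 to compound 3 (within the scatter). Compound 3 is therefore estimated at 8% in this assay, with a range from 0% to 25%.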

Compound 3, a percentage reported as activity, at one concentration (the size of the read-out at that concentration, not a potency): 43%
The estimate for compound 3 lay 35 percentage points below the measured number; measured number outside the range, above it.
By their numbers in this assay, from the lowest: compounds 1 and 2 (each within the scatter of the next); then compound 3.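

For the compounds shown here, this position, an aromatic carbon of a five-membered aromatic ring with 1 nitrogen and 1 sulfur, is the first place where a single change is seen to move the read-out: in this assay the swap to 3-chlorophenyl gives a number 34.7 percentage points higher from compound 2 to compound 3 (beyond the scatter) and so lies beyond the scatter. Both groups carry a chlorine, yet the five-membered aromatic ring with 1 hetero atom gives way to a six-membered aromatic ring of carbon only, so the ring and the place of the chlorine change together and this one step cannot separate them. No measurement at hand bears on the cause of this step.

From the compounds shown here alone, how much of the step belongs to the ring itself and how much to the chlorine remains open. An unsubstituted phenyl, or a methoxy or nitrile in place of the chlorine, would bear on that question.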